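The source may report more compounds than this note shows. Statements on the series, on what has been measured and on what is new or still open speak of the compounds shown alone.

Measured so far:
compound 1 `CC(C)=CCC[C@H](C)c1ccc(C)cc1O` – in a functional assay on MDA-MB-231 cells (Homo sapiens) for inhibition, read by MTT assay, with a stated time of 72 h (a lower number here means a stronger inhibitor, a higher number a weaker inhibitor), compound 1 reaches only the limit > 50000 nM.
compound 2 `CC(C)=CCC[C@H](C)c1ccc(C)c(CNCCO)c1O` – in this assay compound 2 gives 14400 nM.

Within the data shown here, compound 2 holds the only numerical value in this assay; the one other entry is a limit, and so compound 2 cannot be ranked against anything measured. Among the measured compounds shown here, the single computed step, an at least 3.4-fold lower number from compound 1 to compound 2 (0.54 log units; beyond the scatter), shows that a basic side chain on the aromatic carbon carries the series from the limit to a number; the limit itself is the limit of > 50000 nM in this assay, at which 1 of the 2 values shown sits.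

Compound 3 `CC(C)=CCC[C@H](C)c1ccc(C)c(CNCC2CCNCC2)c1O` differs from compound 2 by piperidin-4-yl in place of hydroxymethyl on a saturated chain carbon bound to an amine nitrogen. For the measured compounds named here, no measured step touches this change directly; the only bearing is that compound 2 already carries the amine-bearing side chain, so the step of an at least 3.4-fold lower number from compound 1 to compound 2 (0.54 log units; beyond the scatter) is retained and the piperidine is an extension of it. The expectation for this assay is therefore a step of a 2.1-fold lower number from compound 2 to compound 3 (0.31 log units; beyond the scatter), leaning toward a lower number but with wide uncertainty. Compound 3 is expected to give 7000 nM, within 2000 nM to 25000 nM.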

Compound 3, half-maximal inhibitory concentration: 18300 nM
Beside the measured number, compound 3's estimate is 2.6-fold (0.42 log units) below it; low and high end bracket the measured number.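

On the saturated chain carbon bound to an amine nitrogen, piperidin-4-yl in place of hydroxymethyl gives a 1.3-fold higher number from compound 2 to compound 3 (0.10 log units; within the scatter) in this assay and so the two side chains cannot be told apart in this read-out. The exchange replaces a group of 2 heavy atoms with one of 6 heavy atoms that brings in a six-membered non-aromatic ring, while the counts of hydrogen-bond donors and acceptors stay the same, so this position accepts the ring without the number moving beyond the scatter, and the earlier step of an at least 3.4-fold lower number from compound 1 to compound 2 (0.54 log units; beyond the scatter) is neither extended nor lost. No measured property among the data in hand bears on why the two side chains read alike.

Open, as far as these compounds go, is whether a carboxylic acid, a dimethylamino group or a longer chain at this place would move the number in this assay beyond the scatter. Also open, from the compounds shown here alone, is whether an ether or an amide in place of the amine nitrogen would preserve the step away from the limit held by compound 1.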